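This account rests on a few compounds, and the source may have more. Where it says the series, first, only, none or still open, it means among the compounds named here.

Measured compounds:
- compound 1 `C[C@@H](O)[C@H]1C(=O)N2C(C(=O)OCOC(=O)O[C@@H]3CCc4ccccc43)=C(S[C@@H]3CN[C@H](C(=O)N(C)C)C3)[C@H](C)[C@H]12`: < 0.0167 h
- compound 2 `CC(=O)N1C[C@@H](SC2=C(C(=O)OCOC(=O)O[C@H]3CCCCc4ccccc43)N3C(=O)[C@H]([C@@H](C)O)[C@H]3[C@H]2C)C[C@H]1C(=O)N(C)C`: 0.467 h

Both values come from a physicochemical assay for metabolic stability, read by HPLC, at pH 7.4, tested at 100 uM; on this read-out lower numbers stand for a shorter-lived compound and higher numbers for a longer-lived compound. For compound 1 the entry < 0.0167 h is a limit of the assay rather than a number: the compound was too short-lived to be timed, as the limit of < 0.0167 h in this assay, at which 1 of the 2 values shown sits, shows. Going by the values given here, compound 2, a different member of the same family, gives 0.467 h in this assay, so the two readings sit far apart, though no single step connects them.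

Compound 3 `C[C@@H](O)[C@H]1C(=O)N2C(C(=O)OCOC(=O)O[C@@H]3CCCc4ccccc43)=C(S[C@@H]3CN[C@H](C(=O)N(C)C)C3)[C@H](C)[C@H]12` is the untested partner of compound 1. It differs in one place: 1,2,3,4-tetrahydronaphthalen-1-yl in place of 2,3-dihydro-1H-inden-1-yl on an oxygen next to a carbonyl group. Nothing in the pair already measured isolates this change, so its effect in this assay is open. Since compound 1 stands at a limit, any step can only be read upward or as none. The expectation is a small lift, an at least 1.7-fold higher number from compound 1 to compound 3 (0.25 log units; that floor lies within the scatter), which may still fall inside the usual scatter. Compound 3 is therefore estimated at 0.03 h, within 0.01 h to 0.15 h.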

Compound 3, half-life: 0.025 h
For compound 3 the middle estimate is 1.2-fold (0.08 log units) above the measured one; the range from low to high includes it.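

In this assay, 1,2,3,4-tetrahydronaphthalen-1-yl in place of 2,3-dihydro-1H-inden-1-yl on an oxygen next to a carbonyl group gives an at least 1.4-fold higher number from compound 1 to compound 3 (0.17 log units; that floor lies within the scatter). Going by these compounds alone, this is the first change at this position that can be read on its own, with everything else in the molecule held the same, and compound 3 gives a timed value of 0.025 h. The step can only be read as a floor, and that floor does not by itself separate the change from the scatter, because compound 1 stands at a limit of the assay and not at a number: the limit of < 0.0167 h in this assay, at which 1 of the 3 values shown sits.

Going by these compounds, how large the true step is stays open, as the real half-life of compound 1 is hidden behind its limit. Also open, on these data alone, is what a benzyl group or a straight hexyl chain on an oxygen next to a carbonyl group would give in this assay, and whether the same exchange of rings would give a similar step on the core of compound 2.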